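From Carbamoyl to Pyridin-4-yl on the Side Chain

The source may report more compounds than this note shows. Statements on the series, on what has been measured and on what is new or still open speak of the compounds shown alone.

In a functional assay on a cell-free system (plasma, Oryctolagus cuniculus) for inhibition, with stated times of 5 min, 1 min and 6 min (a higher number here means a weaker inhibitor, a lower number a stronger inhibitor), compound 1 `C=CCOn1c(-c2cccc(C#N)c2)nc(C)c1C(=O)OCC` gives 5860 nM and compound 2 `CCOC(=O)COn1c(-c2cccc(C#N)c2)nc(C)c1C(=O)OCC` gives 6800 nM as measured values. Compound 3 `CCOC(=O)c1c(C)nc(-c2cccc(C#N)c2)n1OCC(N)=O` stands at > 30000 nM as a limit of the assay and not a number. Compound 4 `CCOC(=O)c1c(C)nc(-c2cccc(C#N)c2)n1OCc1ccncc1` carries pyridin-4-yl in place of carbamoyl on a saturated chain carbon bound to an oxygen on an aromatic ring. For the measured compounds named here, three measured steps bear on this: carbamoyl in place of vinyl gave an at least 5.1-fold higher number from compound 1 to compound 3 (0.70 log units; beyond the scatter) and amino in place of ethoxy gave an at least 4.4-fold higher number from compound 2 to compound 3 (0.64 log units; beyond the scatter) whereas ethoxycarbonyl in place of vinyl gave only a 1.2-fold higher number from compound 1 to compound 2 (0.06 log units; within the scatter) in this series. With carbamoyl gone, the step expected in this assay is an at least 5.0-fold lower number from compound 3 to compound 4 (0.69 log units; beyond the scatter) toward a lower number. Compound 4 is estimated at 6000 nM (expected range 1800 nM to 20000 nM).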

Compound 4, half-maximal inhibitory concentration: 6200 nM
Beside the measured number, compound 4's estimate is 1.0-fold (0.01 log units) below it; low and high end bracket the measured number.
By their numbers in this assay, from the lowest: compounds 1, 4 and 2 (each within the scatter of the next). At a limit, above all of these: compound 3.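

Pyridin-4-yl in place of carbamoyl gives an at least 4.8-fold lower number from compound 3 to compound 4 (0.68 log units; beyond the scatter), so the loss seen with carbamoyl does not apply to every new group at this position. Compound 3 stands at a limit of the assay, so this step gives only a minimum size: the limit of > 30000 nM in this assay, at which 1 of the 4 values shown sits. Compound 4 also matches the other two compounds, with a 1.1-fold lower number from compound 2 to compound 4 (0.04 log units; within the scatter) and a 1.1-fold higher number from compound 1 to compound 4 (0.02 log units; within the scatter), so among these four side chains only carbamoyl stands apart.

Still open, going by these compounds, is whether a phenyl, a pyridin-3-yl or a carboxylic acid on this chain carbon would behave like compound 4 or like compound 3.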